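The source may report more compounds than this note shows. Statements on the series, on what has been measured and on what is new or still open speak of the compounds shown alone.

Compound 1 `Oc1ccccc1-c1cc(-c2ccccc2C(F)(F)F)cc(-c2ccccc2O)n1` gives 22500 nM in a functional assay on T47D cells (Homo sapiens) for inhibition; on this read-out higher numbers stand for weaker inhibition and lower numbers for stronger inhibition. Compound 2 `Oc1ccccc1-c1cc(-c2ccc(C(F)(F)F)cc2)cc(-c2ccccc2O)n1` has the same atoms joined differently: 4-(trifluoromethyl)phenyl in place of 2-(trifluoromethyl)phenyl on an aromatic carbon. For compound 2 this assay returns only a limit, > 50000 nM. The step of an at least 2.2-fold higher number from compound 1 to compound 2 (0.34 log units; beyond the scatter) therefore rests on (the limit of > 50000 nM in this assay, at which 1 of the 3 values shown sits). Compound 3 `Oc1ccccc1-c1cc(-c2ccccc2OC(F)(F)F)cc(-c2ccccc2O)n1` differs from compound 1 by trifluoromethoxy in place of trifluoromethyl on an aromatic carbon, and in this assay compound 3 gives 1730 nM, a step of a 13-fold lower number from compound 1 to compound 3 (1.11 log units; beyond the scatter). Compound 4 `Oc1ccccc1-c1cc(-c2ccc(OC(F)(F)F)cc2)cc(-c2ccccc2O)n1` is not yet measured; it stands to compound 2 as compound 3 stands to compound 1: trifluoromethoxy in place of trifluoromethyl on an aromatic carbon. The surroundings differ, ortho to a large group in one case and para to a large group in the other, so this is the same kind of change, not the same one. The expected step is an at least 4.1-fold lower number from compound 2 to compound 4 (0.61 log units; beyond the scatter), resting on a 13-fold lower number from compound 1 to compound 3 (1.11 log units; beyond the scatter) and on the limit of compound 2 > 50000 nM. For compound 4 the estimate in this assay is 12000 nM, between 3500 nM and 50000 nM.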

Compound 4, half-maximal inhibitory concentration: > 50000 nM
Compound 4: a limit, no number; the forecaster's own chance of this, stated with the estimate: 25%; middle value at least 4.1-fold (0.61 log units) away from the limit.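

No step can be read between compound 2 and compound 4, since each returns only a limit: the limit of > 50000 nM in this assay, at which 2 of the 4 values shown sit. The compounds shown leave open whether trifluoromethoxy in place of trifluoromethyl changes inhibition at all when para to a large group.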